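The compounds below may be only part of what the source reports. "The series", "measured", "known", "first", "only" and "open" are said of these compounds alone.

Compound 3 `Cc1ccc(-n2nncc2CN2C(=O)C3(C(C#N)=C(N)Oc4c3c3nc5ccccc5nc3c3ccccc43)c3ccccc32)c(C)c1` stands on a shared core that carries a five-membered aromatic ring with three nitrogen atoms, and on one of those nitrogens sits a 2,4-dimethylphenyl group. In a functional assay on MCF7 cells (Homo sapiens) for antiproliferative activity, read by MTT assay, with a stated time of 48 h (a higher number here means a weaker inhibitor, a lower number a stronger inhibitor), compound 3 gives > 50000 nM, which is a limit of the assay and not a number. Compound 1 `N#CC1=C(N)Oc2c(c3nc4ccccc4nc3c3ccccc23)C12C(=O)N(Cc1cnnn1-c1ccccc1Cl)c1ccccc12` carries a 2-chlorophenyl group at the same place. In this assay compound 1 gives > 50000 nM, again a limit. Compound 2 `Cc1ccc(-n2nncc2CN2C(=O)C3(C(C#N)=C(N)Oc4c3c3nc5ccccc5nc3c3ccccc43)c3ccccc32)cc1C` carries a 3,4-dimethylphenyl group there. In this assay compound 2 gives > 50000 nM, also a limit. For the measured compounds named here, the three steps, a step that the two limits leave unreadable from compound 1 to compound 2, a step that the two limits leave unreadable from compound 1 to compound 3, and a step that the two limits leave unreadable from compound 2 to compound 3, therefore cannot be sized, because the limit of > 50000 nM in this assay, at which 3 of the 3 values shown sit, applies to every value shown; all three compounds sit at the same limit, and no compound is seen to be stronger or weaker than another. Compound 4 `N#CC1=C(N)Oc2c(c3nc4ccccc4nc3c3ccccc23)C12C(=O)N(Cc1cnnn1-c1ccc(Cl)c(Cl)c1)c1ccccc12` is the next member: 3,4-dichlorophenyl in place of 2,4-dimethylphenyl on an aromatic nitrogen. Going by the values given here, no measured step shows a swap from a methyl-bearing phenyl to a chlorine-bearing phenyl, since every such swap among compounds 1, 2 and 3 stays at the limit. It is therefore expected that compound 4 shows no readable step, with an expected step that the limit leaves unreadable from compound 3 to compound 4. Compound 4 is estimated at 60000 nM, within a range from 15000 nM to 250000 nM.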

Compound 4, half-maximal inhibitory concentration: > 50000 nM
Compound 4 was reported as a limit (the forecaster's own chance of this, stated with the estimate: 85%); the middle value is on the limit's open side.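

Compound 4 gives a limit and not a number, so the steps to it from compound 1, compound 2 and compound 3 cannot be read, because all four compounds share one limit in this assay: the limit of > 50000 nM in this assay, at which 4 of the 4 values shown sit. The compounds shown leave open how far apart these four truly lie, and whether any group at this place gives a measurable value.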